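The compounds below may be only part of what the source reports. "The series", "measured", "known", "first", "only" and "open" are said of these compounds alone.

Compound 1 `COc1cc(-n2cnc3ccc(-c4ccccc4)cc32)cc(OC)c1OC` gives 290 nM in a functional assay on SGC-7901 cells (Homo sapiens) for antiproliferative activity, read by MTT assay, with a stated time of 72 h; a higher number here means a weaker inhibitor, a lower number a stronger inhibitor; compound 2 `COc1cc(-n2cnc3ccc(-c4cccc(C)c4C)cc32)cc(OC)c1OC` gives 3040 nM.

Compound 2 stands highest of the two numbers measured, its nearest neighbour being compound 1. For the measured compounds named here, the single step known, a 10-fold higher number from compound 1 to compound 2 (1.02 log units; beyond the scatter), bears directly on the next change: compound 3 `COc1cccc(-c2ccc3ncn(-c4cc(OC)c(OC)c(OC)c4)c3c2)c1` differs from compound 2 by 3-methoxyphenyl in place of 2,3-dimethylphenyl on an aromatic carbon. Since the 2,3-dimethylphenyl group brought the large rise from compound 1, and the 3-methoxyphenyl group carries only one substituent, a lower number is expected for compound 3, as a 4.3-fold lower number from compound 2 to compound 3 (0.64 log units; beyond the scatter), though not a full return to compound 1. Compound 3 is estimated at 700 nM, within 200 nM to 2500 nM.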

Compound 3, half-maximal inhibitory concentration: 3310 nM
Estimate against measurement, compound 3: 4.7-fold (0.67 log units) below; the whole stated range lies below it.
By their numbers in this assay, from the lowest: compound 1; then compounds 2 and 3 (each within the scatter of the next).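

In this assay, 3-methoxyphenyl and 2,3-dimethylphenyl on this aromatic carbon cannot be told apart, with a 1.1-fold higher number from compound 2 to compound 3 (0.04 log units; within the scatter). Adding a single methoxy to the phenyl of compound 1 gives an 11-fold higher number from compound 1 to compound 3 (1.06 log units; beyond the scatter), so among these compounds, the large rise does not require the two methyl groups of compound 2. Nothing available gives a reason for this result. Still open, on these data alone, is whether another substituent on this phenyl, such as an amine or a carboxylic acid, would also bring a rise from compound 1, and whether moving the methoxy elsewhere on the ring would change the number.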